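Exchanging the Aryl Group on an Aromatic Nitrogen of Compound 2

The compounds below may be only part of what the source reports. "The series", "measured", "known", "first", "only" and "open" are said of these compounds alone.

Compound 2, `CCOC(=O)C1=Cc2ccccc2OC1(OCc1cn(-c2cccc(OC)c2)nn1)C(F)(F)F`, has no measured number in a functional assay on MCF7 cells (Homo sapiens) for inhibition, read by MTT assay, with a stated time of 24 h; a lower number here means a stronger inhibitor, a higher number a weaker inhibitor; it sits only at the limit > 150000 nM. Compound 1, `CCOC(=O)C1=Cc2ccccc2OC1(OCc1cc(-c2ccc(C)cc2)no1)C(F)(F)F`, likewise gives only the limit > 150000 nM. Both shown values therefore rest at the same limit (the limit of > 150000 nM in this assay, at which 2 of the 2 values shown sit). Compound 3, `CCOC(=O)C1=Cc2ccccc2OC1(OCc1cn(CC(=O)Nc2ccc(OC)cc2)nn1)C(F)(F)F`, differs from compound 2 by ((4-methoxyphenyl)carbamoyl)methyl in place of 3-methoxyphenyl on an aromatic nitrogen. Among the compounds with values here, no step between measured compounds exists, and with both known values at the limit, no change beyond the scatter is expected. The expected step is a step that the limit leaves unreadable from compound 2 to compound 3, none beyond the scatter. Compound 3 is estimated at 200000 nM, within 50000 nM to 1000000 nM.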

Compound 3, half-maximal inhibitory concentration: 28100 nM
Compound 3: middle estimate off by 7.1-fold (0.85 log units), on the high side; measured number below the stated range.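

In this assay, ((4-methoxyphenyl)carbamoyl)methyl in place of 3-methoxyphenyl on an aromatic nitrogen gives an at least 5.3-fold lower number from compound 2 to compound 3 (0.72 log units; beyond the scatter). Compound 3 is the only compound shown with a measured number, so a change at this position can bring the read-out off the limit. The size of the step stays open at one end, as it starts from a limit: the limit of > 150000 nM in this assay, at which 2 of the 3 values shown sit.

The change alters the group in several ways at once, so the compounds shown do not separate the part played by the amide from that of the methoxy group's place on the ring. They also leave open how a benzyl group or a carboxylic acid on this aromatic nitrogen would read.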